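Chloro for amino on the shared core: expected cytotoxicity

The compounds below may be only part of what the source reports. "The series", "measured", "known", "first", "only" and "open" are said of these compounds alone.

Compound 1 `Nc1nc(Cl)c2ncn(Cc3ccccc3CCl)c2n1` is the reference point. In a functional assay on HCT-116 cells (Homo sapiens) for cytotoxicity, read by sulforhodamine B assay, with a stated time of 48 h (on this read-out lower numbers stand for higher toxicity in this test and higher numbers for lower toxicity in this test), compound 1 gives > 100000 nM, which is a limit of the assay and not a number. Compound 1 therefore stands only at the limit of > 100000 nM in this assay, at which 1 of the 3 values shown sits, with no single number of its own. Compound 2 `ClCc1ccccc1Cn1cnc2nc(Cl)nc(Cl)c21` has "not determined" (no result reported) in this assay. Compound 3 `ClCc1ccccc1Cn1cnc2ncnc(Cl)c21` gives 40700 nM in this assay. Compound 4 `ClCc1ccccc1Cn1cnc2c(Cl)nc(Cl)nc21` differs from compound 1 by chloro in place of amino on an aromatic carbon. Among the compounds with values here, no step between measured compounds is available, so the expected change is judged from compound 3 alone. A step toward higher toxicity of an at least 3.3-fold lower number from compound 1 to compound 4 (0.52 log units; beyond the scatter) is expected because compound 3 gives 40700 nM without the amino group. Compound 4 is estimated at 30000 nM, within 10000 nM to 100000 nM.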

Compound 4, concentration lethal to 50% of the cells: 750 nM
Estimate against measurement, compound 4: 40-fold (1.60 log units) above; measured number outside the range, below it.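

In this assay, within the data shown here, chloro in place of amino on an aromatic carbon between two ring nitrogen atoms gives an at least 130-fold lower number from compound 1 to compound 4 (2.12 log units; beyond the scatter), the first single-place change. The group on this carbon alone therefore moves the read-out strongly toward higher toxicity, with compound 4 at 750 nM. The value of compound 1 is a limit and not a number: the limit of > 100000 nM in this assay, at which 1 of the 4 values shown sits.

The compounds shown leave open how bromo, methoxy or dimethylamino on this carbon would compare with chloro and amino.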